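The source may hold more compounds than are shown below. What is called first, only, known or untested is meant among the compounds shown, and "the series" means these compounds.

Measured compounds:
compound 1 `Cc1c(Nc2ccc(C#N)cc2Cl)ncnc1OC1CC2COCC(C1)N2S(=O)(=O)C1CC1`: 64%
compound 2 `COc1c(Nc2ccc(C#N)cc2Cl)ncnc1OC1C2COCC1CN(C(=O)OC1(C)CC1)C2`: 88%

In a functional assay on HEK293 cells for agonist activity at Glucose-dependent insulinotropic receptor (Homo sapiens), read by fluorescence and cAMP accumulation, with a stated time of 30 min (on this read-out higher numbers stand for larger maximal responses and lower numbers for smaller maximal responses), compound 2 gives 88%, the higher of the two numbers, while compound 1 gives 64%, a gap that lies beyond the usual scatter. Compound 3 `COc1c(Nc2ccc(C#N)cc2F)ncnc1OC1C2COCC1CN(C(=O)OC1(C)CC1)C2` differs from compound 2 by fluoro in place of chloro on an aromatic carbon. For the measured compounds named here, no measured pair shows this change, so only a small step is expected, a number 6 percentage points lower from compound 2 to compound 3 (within the scatter), not reaching beyond the scatter in either direction. Compound 3 is therefore expected to give 82% in this assay, within a range from 62% to 100%.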

Compound 3, largest response reached (reported as percent of maximum), in percent of the reference or control that the assay uses: 99%
For compound 3 the middle estimate is 17 percentage points below the measured one; measured number inside the range.
By their numbers in this assay, from the lowest: compound 1; then compound 2; then compound 3.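

Swapping one halogen at this ring position, ortho to a large group and meta to a cyano group, changes the maximal response in this assay: fluoro in place of chloro gives a number 11 percentage points higher from compound 2 to compound 3 (beyond the scatter). This is the first single-place comparison here, so the position is shown to matter, though only through this one pair. No measurement here explains the step. Going by these compounds, how a methyl or methoxy group at this position would behave remains open. So does whether the same swap would have a similar effect on the core of compound 1.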